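The source may report more compounds than this note shows. Statements on the series, on what has been measured and on what is new or still open speak of the compounds shown alone.

Compound 1 `COc1cc(-c2cc(COCc3cn(Cc4cc(-c5ccc(C)cc5)cnc4Cl)nn3)on2)cc(OC)c1OC` gives 35300 nM in a functional assay on HeLa cells (Homo sapiens) for cytotoxicity, read by MTT assay, with a stated time of 48 h (on this read-out higher numbers stand for weaker inhibition and lower numbers for stronger inhibition), as its measured reading. In this assay compound 2 `COc1cc(C2=NOC(COCc3cn(Cc4cc(C)cnc4Cl)nn3)C2)cc(OC)c1OC` gives 50500 nM as its reading. These two numbers lie within the usual scatter of each other, so compound 1 stands level with compound 2 and neither can be ranked over the other.

Compound 3 `COc1cc(-c2cc(COCc3cn(Cc4cc(-c5ccc(F)cc5)cnc4Cl)nn3)on2)cc(OC)c1OC` differs from compound 1 in one place, fluoro in place of methyl on an aromatic carbon being fluoro in place of methyl on an aromatic carbon, para to a large group. The 4-methylphenyl of compound 1 thus becomes 4-fluorophenyl, and the rest of the structure stays the same.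

Among the compounds with values here, no pair of measured compounds shows what this exchange does. In this assay no step beyond the scatter is expected, and neither direction is favoured. The estimate therefore stays close to compound 1 at 35300 nM as its only anchor. The step of a 1.0-fold lower number from compound 1 to compound 3 (0.00 log units; within the scatter) is estimated to remain within the scatter. Compound 3 is expected at 35000 nM in this reading, with an estimated range from 15000 nM to 80000 nM around that middle.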

Compound 3, half-maximal inhibitory concentration: 37300 nM
Beside the measured number, compound 3's estimate is 1.1-fold (0.03 log units) below it; measured number inside the range.
By their numbers in this assay, from the lowest: compounds 1, 3 and 2 (each within the scatter of the next).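

Within the data shown here, until now no two measured compounds differed in one place, so this pair gives the first direct reading of a change on the aromatic carbon para to a large group. In this assay, 4-methylphenyl to 4-fluorophenyl appears as a 1.1-fold higher number from compound 1 to compound 3 (0.02 log units; within the scatter), which places the two compounds level. Methyl and fluoro therefore cannot be told apart at this position on this read-out, at least on the core of compound 1, and no other kind of measurement is available to explain this result.

With only these two groups shown at this place, the effect of a larger or differently built group, such as an amine, a carboxylic acid or a longer alkyl chain, remains open. From the compounds shown here alone, it also remains open whether any exchange at this position can produce a step beyond the scatter, and whether methyl and fluoro would stay level on a different core.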